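This account rests on a few compounds, and the source may have more. Where it says the series, first, only, none or still open, it means among the compounds named here.

Measured so far:
- compound 1, `COc1ccccc1N1CCN(CCCNC(=O)NN(Cc2ccccc2F)c2ccc(F)cc2)CC1`, gives 3.6 nM in an assay on CHO cells for displacement of a labelled ligand from D(4) dopamine receptor (Homo sapiens), read by radioligand binding; a higher number here means a weaker inhibitor, a lower number a stronger inhibitor
- compound 2, `COc1ccccc1N1CCN(CCCNC(=O)NN(Cc2ccccc2)c2ccc(Cl)cc2)CC1`, gives 2.9 nM in this assay

Compound 2 holds the lowest of the two numbers in this assay, and the nearest is compound 1, whose number is higher by an amount that lies within the usual scatter of such measurements, so the two compounds cannot be told apart on these data.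

Compound 3, `COc1ccccc1N1CCN(CCCNC(=O)NN(Cc2ccccc2F)c2ccc(Cl)cc2)CC1`, has not yet been measured. It differs from compound 2 in one place: fluoro in place of hydrogen on an aromatic carbon. Among the measured compounds shown here, no pair of measured compounds shows this change on its own, so its size cannot be read from an existing step. Compound 1 already carries the 2-fluorobenzyl group together with a fluoro on the other ring, and compound 1 in this assay gives 3.6 nM, close to compound 2. On that ground compound 3 is expected to stay near the number of compound 2, with an estimated step of a 1.0-fold higher number from compound 2 to compound 3 (0.01 log units; within the scatter) that is not beyond the scatter. The estimate for compound 3 in this assay is 3 nM, with a range from 1.5 nM to 6.5 nM.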

Compound 3, inhibition constant: 2.6 nM
Beside the measured number, compound 3's estimate is 1.2-fold (0.06 log units) above it; the measured number falls inside the stated range.
By their numbers in this assay, from the lowest: compounds 3, 2 and 1 (each within the scatter of the next).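

In this assay the change from benzyl to 2-fluorobenzyl can now be read on its own, with the chloro held fixed, and it amounts to a 1.1-fold lower number from compound 2 to compound 3 (0.05 log units; within the scatter), so a fluoro at this place leaves the number inside the scatter. The second new comparison keeps the 2-fluorobenzyl group and exchanges the other halogen, chloro in place of fluoro on an aromatic carbon, and it gives a 1.4-fold lower number from compound 1 to compound 3 (0.14 log units; within the scatter), so this exchange also cannot be told apart from no change at all. Nothing measured alongside these binding numbers bears on what lies behind either step.

The compounds shown leave open whether the number would stay put with a larger group at this place, such as a methoxy or a trifluoromethyl in place of the fluoro. They also say nothing about an amine or a carboxylic acid on this ring, or about a longer chain in place of the benzyl group, so the flat picture holds only for these three halogen and hydrogen variants.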